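Urea-linked thienopyrimidines: ortho halogen swap on the terminal phenyl

The compounds below may be only part of what the source reports. "The series", "measured", "known", "first", "only" and "open" are said of these compounds alone.

Measured so far:
- compound 1, `CN(C)CCCNc1nc(-c2ccc(NC(=O)Nc3ccccc3F)cc2)nc2ccsc12`: 660 nM
- compound 2, `CN(C)CCCNc1nc(-c2ccc(NC(=O)Nc3ccc(F)cc3)cc2)nc2c(Cl)c(Cl)sc12`: 980 nM

Both numbers come from a functional assay on MDA-MB-231 cells (Homo sapiens) for cytotoxicity, read by MTT assay, with a stated time of 72 h; a higher number here means a weaker inhibitor, a lower number a stronger inhibitor. Compound 1 holds the lower of the two values, but compound 2 sits within the scatter of it, so no order between them can be read. Compound 2 also differs from compound 1 in more than one place, so nothing is attributed to either change.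

Compound 3, `CN(C)CCCNc1nc(-c2ccc(NC(=O)Nc3ccccc3Cl)cc2)nc2ccsc12`, is the next analogue. Compared with compound 1 it carries chloro in place of fluoro on an aromatic carbon. Among the compounds with values here, no step between measured compounds covers this change, so the expectation for this assay rests on the size of the groups alone; a step no larger than the scatter, in either direction, is expected. Compound 3 is therefore estimated at 600 nM, with a range of 250 nM to 1500 nM, meaning a step of a 1.1-fold lower number from compound 1 to compound 3 (0.04 log units; within the scatter) from compound 1.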

Compound 3, half-maximal inhibitory concentration: 590 nM
Compound 3: the middle estimate sits 1.0-fold (0.01 log units) above what was measured; the measured number falls inside the stated range.
By their numbers in this assay, from the lowest: compounds 3, 1 and 2 (each within the scatter of the next).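

Replacing 2-fluorophenyl with 2-chlorophenyl gives a 1.1-fold lower number from compound 1 to compound 3 (0.05 log units; within the scatter) in this assay. Within the data shown here, this is the first comparison that differs in one place only, and at this aromatic carbon, ortho to a large group, the two halogens cannot be told apart in this read-out. The step therefore shows that fluoro and chloro at this position give values within the scatter of each other, but no measurement here explains that result.

Still open, going by these compounds, is whether methyl, methoxy or an amine on this aromatic carbon would read apart from the two halogens in this assay. Also open, on these data alone, is whether the same halogen swap would read alike on the core of compound 2.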